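Methyl in Place of Hydrogen on the Ester Chain

The source may report more compounds than this note shows. Statements on the series, on what has been measured and on what is new or still open speak of the compounds shown alone.

Among the compounds with values here, compound 2 `COC(=O)c1ccc(-c2cc(N3CCC(CCNS(N)(=O)=O)CC3)ncn2)cc1` stands lowest of the two numbers measured so far: in a functional assay on MCF7 cells (Homo sapiens) for antiproliferative activity, read by sulforhodamine B assay, with a stated time of 48 h (on this read-out higher numbers stand for weaker inhibition of growth and lower numbers for stronger inhibition of growth), compound 2 gives 17600 nM, whereas compound 1 `COc1ccc(-c2cc(N3CCC(CCNS(N)(=O)=O)CC3)ncn2)cc1` gives 56600 nM. Within the data shown here, the only measured step, a 3.2-fold lower number from compound 1 to compound 2 (0.51 log units; beyond the scatter), concerns the aromatic substituent, not the ester chain. Compound 3 `CCOC(=O)c1ccc(-c2cc(N3CCC(CCNS(N)(=O)=O)CC3)ncn2)cc1` differs from compound 2 by methyl in place of hydrogen on a saturated chain carbon bound to an oxygen next to a carbonyl group, that is methoxycarbonyl to ethoxycarbonyl. Among the measured compounds shown here, no measured step bears on this change, so the expected step from compound 2 to compound 3 is a 1.2-fold lower number from compound 2 to compound 3 (0.07 log units; within the scatter), within the scatter. Compound 3 is estimated at 15000 nM, ranging from 6000 nM to 40000 nM.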

Compound 3, concentration for 50% growth inhibition: 6200 nM
Compound 3: the middle estimate sits 2.4-fold (0.38 log units) above what was measured; measured number inside the range.
By their numbers in this assay, from the lowest: compound 3; then compound 2; then compound 1.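

In this assay the ester chain proves to be a place that responds: methyl in place of hydrogen on a saturated chain carbon bound to an oxygen next to a carbonyl group gives a 2.8-fold lower number from compound 2 to compound 3 (0.45 log units; beyond the scatter), a step beyond the scatter. Replacing the methoxy group with the ethyl ester gives a 9.1-fold lower number from compound 1 to compound 3 (0.96 log units; beyond the scatter), so the change from the methoxy group reaches further with the ethyl ester than with the methyl ester. Nothing on hand explains the step. The compounds shown leave open what a longer chain on the ester oxygen would give, and what a carboxylic acid or an amide would give in place of the ester.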